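The source may report more compounds than this note shows. Statements on the series, on what has been measured and on what is new or still open speak of the compounds shown alone.

Measured in a functional assay on SK-BR-3 cells (Homo sapiens) for inhibition, read by CellTiter-Glo, with a stated time of 72 h; on this read-out lower numbers stand for stronger inhibition and higher numbers for weaker inhibition:
compound 1 `COc1cncc(-c2ccnc3c2c(C(C)C)nn3-c2ccc(C(N)=O)c(N[C@H]3CC[C@H](O)CC3)c2)c1`: 451 nM
compound 2 `CC(C)c1nn(-c2ccc(C(N)=O)c(N[C@H]3CC[C@H](O)CC3)c2)c2cccc(-c3cnc4ccccc4c3)c12`: 39 nM
compound 3 `CC(C)c1nn(-c2ccc(C(N)=O)c(N[C@H]3CC[C@H](O)CC3)c2)c2cncc(-c3cnc4ccccc4c3)c12`: 473 nM

Compound 1 stands level with compound 3, the two numbers lying within the scatter of each other, while its number lies beyond the scatter above that of compound 2. The step followed here leads to compound 4 `CC(C)c1nn(-c2ccc(C(N)=O)c(N[C@H]3CC[C@H](O)CC3)c2)c2nccc(-c3ccsc3)c12`. The change is thiophen-3-yl in place of 5-methoxypyridin-3-yl on an aromatic carbon, opposite the ring nitrogen. Going by the values given here, no pair of measured compounds isolates this swap, so the data give no direct guide to its size. Compound 2, at 39 nM, shows that much lower numbers occur in this small set, but it differs from compound 1 in more than one place. In this assay, therefore, no step beyond the scatter is expected, with a slight lean towards a lower number. The estimated change is a 1.3-fold lower number from compound 1 to compound 4 (0.11 log units; within the scatter). For compound 4 the expected value is 350 nM, with an estimated range from 120 nM to 1000 nM.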

Compound 4, half-maximal inhibitory concentration: > 10000 nM
Compound 4: a limit, no number; the forecaster's own chance of this, stated with the estimate: 2%; middle value at least 28-fold (1.45 log units) from the limit.
By their numbers in this assay, from the lowest: compound 2; then compounds 1 and 3 (each within the scatter of the next). At a limit, above all of these: compound 4.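

In this assay compound 4 gives > 10000 nM, which is a limit of the assay and not a number: the limit of > 10000 nM in this assay, at which 1 of the 4 values shown sits. At this aromatic carbon, opposite the ring nitrogen, thiophen-3-yl in place of 5-methoxypyridin-3-yl gives an at least 22-fold higher number from compound 1 to compound 4 (1.34 log units; beyond the scatter), a step with a lower bound only. This is the one pair shown that isolates a change at this place, and it shows that a single swap of the group there can take a compound from a measured value to the limit.

The step changes the ring size and removes the methoxy group together, so the compounds shown do not separate these two changes. As far as these compounds go, it stays open whether an unsubstituted pyridin-3-yl or a phenyl group at this place would stand with compound 1 or with compound 4.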